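The source may report more compounds than this note shows. Statements on the series, on what has been measured and on what is new or still open speak of the compounds shown alone.

Three compounds were measured in a functional assay on the whole organism (strain Wistar albino) for inhibition, with Rattus norvegicus as the target, read by paw edema, with stated times of 1 h and 3 h, at a dose of 0.32 mmol/kg by the intraperitoneal route; on this read-out lower numbers stand for less inhibition and higher numbers for more inhibition at the one dose given (going by the name of the read-out). Compound 1 `Cc1ccc(-c2nn(-c3ccc(Cl)cc3)cc2-c2cc(-c3ccc(Cl)cc3)[nH]c2-c2ccc(F)cc2)cc1` gave 21%, and compound 2 `COc1ccc(-c2[nH]c(-c3ccc(Cl)cc3)cc2-c2cn(-c3ccc(Cl)cc3)nc2-c2ccc(C)cc2)cc1` gave 21.3%. The change between them is methoxy in place of fluoro on an aromatic carbon, and it made the step of a number 0.3 percentage points higher from compound 1 to compound 2 (within the scatter). Compound 3 `COc1ccc(-c2nn(-c3ccc(S(N)(=O)=O)cc3)cc2-c2cc(-c3ccc(Cl)cc3)[nH]c2-c2ccc(F)cc2)cc1` gave 55.9%, the highest of the three; the difference between the core of compound 3 and that of compound 1 is not broken down here. Compound 4 `COc1ccc(-c2nn(-c3ccc(S(N)(=O)=O)cc3)cc2-c2cc(-c3ccc(Cl)cc3)[nH]c2-c2ccc(OC)cc2)cc1` has not yet been measured in this assay. It differs from compound 3 by methoxy in place of fluoro on an aromatic carbon, the same change as that between compound 1 and compound 2, at a place described in identical terms. Within the data shown here, compound 4 is expected to show a number 0.1 percentage points higher from compound 3 to compound 4 (within the scatter), because the one earlier instance of this change gave a number 0.3 percentage points higher from compound 1 to compound 2 (within the scatter). Compound 4 is therefore estimated at 56%, with a range from 42% to 70%.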

Compound 4, a percentage reported as inhibition, in the whole organism at one dose (the size of the read-out at that dose, not a potency): 28.6%
Estimate against measurement, compound 4: 27.4 percentage points above, outside the stated range (below it).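

In this assay, the change from 4-fluorophenyl to 4-methoxyphenyl on the core of compound 3 gave a number 27.3 percentage points lower from compound 3 to compound 4 (beyond the scatter). Among these compounds, the step measured on one core therefore did not carry over to the other, and the two instances differ: the same change on two cores in this assay, a number 0.3 percentage points higher (within the scatter) from compound 1 to compound 2 and a number 27.3 percentage points lower (beyond the scatter) from compound 3 to compound 4, 27.6 percentage points apart, beyond the scatter of two such steps This does not show which feature of the two cores accounts for the gap, and with only one pair on each core it sets no rule for the series.

As far as these compounds go, it remains open how an amine or a carboxylic acid would read in place of fluoro on the core of compound 3. From the compounds shown here alone, it is also open whether a longer chain such as ethoxy would follow methoxy there.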